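Carbamate aryl swap on a hydroxypropyl pyridone scaffold

The source may hold more compounds than are shown below. What is called first, only, known or untested is meant among the compounds shown, and "the series" means these compounds.

Measured compounds:
compound 1, `CC(C)=CCC1Cc2c(OCCCNS(=O)(=O)c3ccc(Br)cc3)cc(=O)n(CCCO)c2CC1(C)C`, 19.5%
compound 2, `COc1ccc(NC(=O)Oc2cc(=O)n(CCCO)c3c2CC(CC=C(C)C)C(C)(C)C3)cc1`, 3.7%
compound 3, `COc1ccccc1NC(=O)Oc1cc(=O)n(CCCO)c2c1CC(CC=C(C)C)C(C)(C)C2`, 71.1%

Three compounds sharing one core were tested in a functional assay on PANC-1 cells (Homo sapiens) for inhibition, read by MTT assay, with a stated time of 24 h, tested at 10 uM; a lower number here means less inhibition, a higher number more inhibition at the concentration tested (going by the name of the read-out). Compound 3 stands highest of the three; its nearest neighbour is compound 1, and the furthest is compound 2, both gaps lying beyond the scatter. For the measured compounds named here, the one single-point comparison within the measured set is a number 67.4 percentage points higher from compound 2 to compound 3 (beyond the scatter), a large step that turns on nothing more than where the methoxy group sits on the phenyl ring attached to the amide-type nitrogen.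

Compound 4, `CC(C)=CCC1Cc2c(OC(=O)Nc3ccc(Cl)c(Cl)c3)cc(=O)n(CCCO)c2CC1(C)C`, is not yet measured. It differs from compound 3 in one place: 3,4-dichlorophenyl in place of 2-methoxyphenyl on an amide-type nitrogen. Going by the values given here, no measured step covers the move from a methoxy-bearing ring to a chlorine-bearing one, so the only guide is that the aryl group on that nitrogen can move the number a great deal, as the step from compound 2 to compound 3 shows. Given that, compound 4 is expected to fall below compound 3, with the step estimated as a number 33.1 percentage points lower from compound 3 to compound 4 (beyond the scatter), though the direction is uncertain. The estimate for compound 4 is 38%, within a range from 5% to 72%.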

Compound 4, a percentage reported as inhibition, at one concentration (the size of the read-out at that concentration, not a potency): 61.4%
Beside the measured number, compound 4's estimate is 23.4 percentage points below it, and the stated range covers the measured number.
By their numbers in this assay, from the lowest: compound 2; then compound 1; then compounds 4 and 3 (each within the scatter of the next).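

In this assay, setting 3,4-dichlorophenyl in place of 2-methoxyphenyl on the amide-type nitrogen gives a number 9.7 percentage points lower from compound 3 to compound 4 (within the scatter) and so shows that a methoxy group on this ring is not required for a high number at this position. Setting the same group in place of 4-methoxyphenyl gives a number 57.7 percentage points higher from compound 2 to compound 4 (beyond the scatter) and so shows that the low number of compound 2 is not shared by either of the other two aryl groups tested on this nitrogen. Nothing available explains why these aryl groups differ in this way.

On these data alone, it remains open how a plain phenyl ring or a cyclohexyl group on the amide-type nitrogen would read, and therefore whether any substituent on the ring is needed. Also open, as far as these compounds go, is whether the carbamate link itself matters, as a urea or simple amide in its place would show.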